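A few compounds are considered here, and "the series" means these few. Any claim that something is new, unique, unknown or untested is made for them only; others in the source may bear on it.

Compound 1 `Cc1cc(C(F)(F)F)ccc1-c1cc2cnn([C@@H](CC(C)C)c3ccc(C(=O)NCCC(=O)O)cc3)c2cc1C`: 80%
Compound 2 `Cc1cc(C(F)(F)F)ccc1-c1cc2cn([C@@H](CC(C)C)c3ccc(C(=O)NCCC(=O)O)cc3)nc2cc1C`: 68%

In an ADME assay on microsomes from liver (Canis lupus familiaris) for metabolic stability, with a stated time of 10 min, tested at 1 uM (a lower number here means that less of the compound is left, a higher number that more of the compound is left), compound 1 stands highest of the two measured compounds at 80%. Compound 2 gives 68%, a gap that lies beyond the usual scatter. Compound 3 `Cc1cc2c(cnn2[C@@H](CC(C)C)c2ccc(C(=O)NCCC(=O)O)cc2)cc1-c1ccc(C(F)(F)F)cc1Cl`, not yet measured, keeps the core of compound 1 and differs from it in one group: chloro in place of methyl on an aromatic carbon. This places chloro in place of methyl on an aromatic carbon, so that 2-methyl-4-(trifluoromethyl)phenyl becomes 2-chloro-4-(trifluoromethyl)phenyl. For the measured compounds named here, no measured pair shows this change on its own, so the data give no direct guide to its size. No shift beyond the scatter is expected in this assay, and the estimated step of a number 2 percentage points higher from compound 1 to compound 3 (within the scatter) is small. The expected value for compound 3 is 82%, with an estimated range from 68% to 93%.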

Compound 3, percent of the compound remaining: 65%
Estimate against measurement, compound 3: 17 percentage points above; the whole stated range lies above it.
By their numbers in this assay, from the lowest: compounds 3 and 2 (each within the scatter of the next); then compound 1.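

In this assay, chloro in place of methyl on this aromatic carbon gives a number 15 percentage points lower from compound 1 to compound 3 (beyond the scatter). The position, ortho to a large group and meta to a trifluoromethyl group, therefore responds to this change, even though one heavy atom replaces one heavy atom and the counted hydrogen-bond donors, acceptors and net charge stay the same. No measurement shown bears on the reason for this step.

The compounds shown leave open whether other groups on this carbon, such as fluoro, methoxy or a nitrile, would stay with methyl or fall with chloro. They also leave open whether the same exchange would give a step of similar size on the core of compound 2.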